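The source may hold more compounds than are shown below. What is called first, only, known or untested is meant among the compounds shown, and "the series" means these compounds.

Compound 2 `COc1cc2c(cc1OC)CN(S(=O)(=O)c1ccc(-n3cc(COc4ccccc4)nn3)cc1)CC2` is one of two measured compounds in this set. In a functional assay on MOLT-3 cells (Homo sapiens) for cytotoxicity, read by MTT assay, with a stated time of 48 h (on this read-out lower numbers stand for stronger inhibition and higher numbers for weaker inhibition), compound 2 gives > 50 ug/mL, which is a limit of the assay rather than a number. Compound 1 `COc1cc2c(cc1OC)CN(S(=O)(=O)c1ccc(-n3cc(COc4ccc(C)cc4)nn3)cc1)CC2` gives > 50 ug/mL, again only a limit. The step that the two limits leave unreadable from compound 1 to compound 2 is therefore unreadable, since both values sit at the limit of > 50 ug/mL in this assay, at which 2 of the 2 values shown sit. Compound 3 `COc1cc2c(cc1OC)CN(S(=O)(=O)c1ccc(-n3cc(CO)nn3)cc1)CC2` differs from compound 2 by hydrogen in place of phenyl on an oxygen on a saturated carbon. For the measured compounds named here, no measured step speaks readably to this change, so neither a direction nor a size can be drawn from the data. Compound 3 is expected to give about 80 ug/mL (range 30 ug/mL to 300 ug/mL), an estimated step that the limit leaves unreadable from compound 2 to compound 3, most probably reported once more as a limit.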

Compound 3, half-maximal inhibitory concentration: > 50 ug/mL
Compound 3 was reported as a limit; the forecaster's own chance of this, stated with the estimate: 85%; the middle value is on the limit's open side.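

No step can be read among compound 1, compound 2 and compound 3, because each value is only a limit: the limit of > 50 ug/mL in this assay, at which 3 of the 3 values shown sit. The compounds shown leave open which structural change, if any, would give a measurable value in this assay.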